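The source may report more compounds than this note shows. Statements on the series, on what has been measured and on what is new or still open speak of the compounds shown alone.

Measured compounds:
compound 1 `COc1cc(C)c(S(=O)(=O)N(C)CCOCC(=O)N2CCN(CCN(C)C)CC2)c(C)c1`: 7.4
compound 2 `COc1cc(C)c(S(=O)(=O)N(C)CCOCC(=O)N2CCC(C(C)(C)CN(C)C)CC2)c(C)c1`: 7.5
compound 3 `COc1cc(C)c(S(=O)(=O)N(C)CCOCC(=O)N2CCN([C@H]3CN4CCC3CC4)CC2)c(C)c1`: 7.2

All three share the same sulfonamide-bearing core and differ only in the basic amine-containing group at the far end. Compound 2 gives the top number of the three in a functional assay on Umbilical vein for antagonist activity at B1 bradykinin receptor (Homo sapiens), using Schild analysis, with a stated time of 30 min (a lower number here means a less potent compound, a higher number a more potent compound, by a factor of ten per unit of this negative logarithm), yet compound 1 sits within the scatter of it, and compound 3 does as well, so the three are not separated in a meaningful way.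

Compound 4 `COc1cc(C)c(S(=O)(=O)N(C)CCOCC(=O)N2CCC(CN3CCN(C)CC3)CC2)c(C)c1` is the next variation: (4-methylpiperazin-1-yl)methyl in place of 1-((dimethylamino)methyl)-1-methylethyl on a saturated ring carbon. Among the compounds with values here, the only measured step that touches the same region is the one from compound 1 to compound 3, which exchanged an open-chain amine group for a ring-containing one on the ring nitrogen and gave a number 0.20 log units lower from compound 1 to compound 3 (within the scatter). That exchange, of similar character to the present one, produced no shift beyond the scatter. On this basis the expectation for compound 4 is no change beyond the scatter, a number 0.10 log units lower from compound 2 to compound 4 (within the scatter), so compound 4 is estimated at 7.4 in this assay, with a range from 6.9 to 7.9.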

Compound 4, negative logarithm of the antagonist equilibrium constant: 8.1
For compound 4 the middle estimate is 0.70 log units below the measured one; measured number outside the range, above it.
By their numbers in this assay, from the lowest: compounds 3, 1 and 2 (each within the scatter of the next); then compound 4.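

Exchanging the 1-((dimethylamino)methyl)-1-methylethyl group for the (4-methylpiperazin-1-yl)methyl group on a saturated ring carbon gives a number 0.60 log units higher from compound 2 to compound 4 (beyond the scatter) in this assay. This is the only step shown here that lies beyond the scatter, so the number does respond to the group at this position. The step swaps an open chain for a ring and also adds a second nitrogen, so this single pair cannot say which of these differences counts.

Still open, on these data alone, is whether a morpholin-4-ylmethyl or piperidin-1-ylmethyl group on the same ring carbon would match compound 4, which would test the need for the second nitrogen. Also open, as far as these compounds go, is whether an ethyl group could replace the methyl on the piperazine. No measurement given here accounts for the rise.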